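The source may report more compounds than this note shows. Statements on the series, on what has been measured and on what is new or still open speak of the compounds shown alone.

Compound 2 `COc1cc(-c2nn(-c3cccc(NC(=O)Nc4ccc(Cl)c(C(F)(F)F)c4)c3)cc2-c2ccncc2)ccc1Cl` gives 980 nM in a functional assay on CCRF-CEM cells (Homo sapiens) for inhibition, read by sulforhodamine B assay, with a stated time of 48 h (a higher number here means a weaker inhibitor of growth, a lower number a stronger inhibitor of growth), the lower of the two numbers shown so far, although the gap to compound 1 `COc1cc(-c2nn(-c3cccc(NC(=O)c4cccc(C(F)(F)F)c4)c3)cc2-c2ccncc2)ccc1Cl`, which gives 1450 nM in this assay, lies within the scatter. Compound 3 `COc1cc(-c2nn(-c3cccc(NC(=O)c4ccccc4)c3)cc2-c2ccncc2)ccc1Cl` has not yet been measured. The change from compound 2 is phenyl in place of (4-chloro-3-(trifluoromethyl)phenyl)amino on a carbonyl carbon. For the measured compounds named here, the only measured step, a 1.5-fold lower number from compound 1 to compound 2 (0.17 log units; within the scatter), touched the same part of the molecule and stayed within the scatter, so it gives little guidance on size or direction. Compound 3 is expected to give 2500 nM, with a range from 800 nM to 8000 nM, an estimated step of a 2.6-fold higher number from compound 2 to compound 3 (0.41 log units; beyond the scatter).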

Compound 3, concentration for 50% growth inhibition: 492 nM
For compound 3 the middle estimate is 5.1-fold (0.71 log units) above the measured one; measured number outside the range, below it.
By their numbers in this assay, from the lowest: compounds 3, 2 and 1 (each within the scatter of the next, the first and the last beyond it).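

Hydrogen in place of trifluoromethyl on an aromatic carbon gives the first step here that clears the scatter, a 2.9-fold lower number from compound 1 to compound 3 (0.47 log units; beyond the scatter), so this substituent is not needed for growth inhibition in this assay. Phenyl in place of (4-chloro-3-(trifluoromethyl)phenyl)amino on a carbonyl carbon gives a 2.0-fold lower number from compound 2 to compound 3 (0.30 log units; within the scatter), so the larger group shows no measurable advantage over the plain phenyl. No data here explain either step. Still open, from the compounds shown here alone, is how a methyl, a methoxy or an amine on the phenyl ring would compare, and whether a cyclohexyl or a short alkyl chain could replace that ring.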